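The source may hold more compounds than are shown below. What is called first, only, known or untested is meant among the compounds shown, and "the series" means these compounds.

Measured so far: compound 1 `Cc1nnc(CN(C)C)n1-c1ccc(Cl)cc1C(=O)c1ccccc1`, 0.5 mg/kg; compound 2 `Cc1nnc(CN(C)C)n1-c1ccccc1C(=O)c1ccccc1Cl`, 5 mg/kg; compound 3 `Cc1nnc(CN2CCCC2)n1-c1ccc(Cl)cc1C(=O)c1ccccc1Cl`, 1.8 mg/kg.

In a functional assay on the whole organism (strain CF-1) for inhibition, with Mus musculus as the target (a higher number here means that more compound is needed for the effect, a lower number that less compound is needed), compound 3 stands second highest of the three numbers, nearest to compound 2, whose number is higher by a margin beyond the scatter, and furthest from compound 1, whose number is lower, also beyond the scatter. Compound 4 `Cc1nnc(CN(C)C)n1-c1ccc(Cl)cc1C(=O)c1ccccc1Cl` differs from compound 3 in one place: dimethylamino in place of pyrrolidin-1-yl on a saturated chain carbon bound to an aromatic carbon. Among the measured compounds shown here, no measured pair isolates this change, so its size is not known from these data. Expected in this assay is a step of a 1.5-fold lower number from compound 3 to compound 4 (0.18 log units; within the scatter), small, within the usual scatter, leaning toward a lower number. Compound 4 is accordingly estimated at 1.2 mg/kg, with a range from 0.35 mg/kg to 4 mg/kg.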

Compound 4, dose for half-maximal effect: 0.14 mg/kg
Compound 4: the middle estimate sits 8.6-fold (0.93 log units) above what was measured; the whole stated range lies above it.
By their numbers in this assay, from the lowest: compound 4; then compound 1; then compound 3; then compound 2.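

In this assay, the amine on the saturated chain carbon matters: dimethylamino in place of pyrrolidin-1-yl gives a 13-fold lower number from compound 3 to compound 4 (1.11 log units; beyond the scatter), a large step. Chloro in place of hydrogen also matters at two different aromatic carbons, giving a 36-fold lower number from compound 2 to compound 4 (1.55 log units; beyond the scatter), a large step, at one and a 3.6-fold lower number from compound 1 to compound 4 (0.55 log units; beyond the scatter), a modest step, at the other. Nothing measured here accounts for these steps.

On these data alone, whether the amine step extends to diethylamino, morpholin-4-yl or a primary amine remains open. So does whether fluoro or methyl could replace either chloro.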